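The source may report more compounds than this note shows. Statements on the series, on what has been measured and on what is new or still open speak of the compounds shown alone.

Working notes on the series built on the shared core of compound 1 `CN1CCN(CCNCc2cn(-c3ccc(F)cc3F)nc2-c2ccc(OC(F)(F)F)cc2)CC1`. In an ADME assay on Huh-7 cells (Homo sapiens) for cytotoxicity (on this read-out lower numbers stand for higher toxicity in this test and higher numbers for lower toxicity in this test), compound 1 gives 18000 nM. Compound 2 `COC(=O)c1ccc(-c2nn(-c3ccc(F)cc3F)cc2CNCCN2CCN(C)CC2)cc1` reaches only a limit of this assay, > 20000 nM. Compound 3 `COc1ccc(-c2nn(-c3ccc(F)cc3F)cc2CNCCN2CCN(C)CC2)cc1` likewise sits at a limit of this assay, > 20000 nM. Compound 3 thus stands at the upper edge of the numbers shown, where the limit of > 20000 nM in this assay, at which 2 of the 3 values shown sit, holds two of the three values. The step to compound 4 `CN1CCN(CCNCc2cn(-c3ccc(F)cc3F)nc2-c2ccccc2)CC1` is hydrogen in place of methoxy on an aromatic carbon. Of the measured steps, an at least 1.1-fold higher number from compound 1 to compound 3 (0.04 log units; that floor lies within the scatter) touches the same place and a step that the two limits leave unreadable from compound 2 to compound 3 is unreadable; neither reveals a shift beyond the scatter. No step beyond the scatter is expected here. Compound 4 is expected to give 25000 nM, between 12000 nM and 60000 nM. The expected step is a step that the limit leaves unreadable from compound 3 to compound 4 in this assay.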

Compound 4, half-maximal cytotoxic concentration: > 20000 nM
Compound 4: only a limit was reported; the forecaster's own chance of this, stated with the estimate: 60%; the middle value is on the limit's open side.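

With hydrogen on this aromatic carbon, the change from 4-methoxyphenyl to phenyl still leaves compound 4 at a limit and not a number in this assay, so this position needs no substituent to reach that limit: the limit of > 20000 nM in this assay, at which 3 of the 4 values shown sit. Within the data shown here, the one readable step is an at least 1.1-fold higher number from compound 1 to compound 4 (0.04 log units; that floor lies within the scatter). The steps from compound 2 and from compound 3 to compound 4 cannot be read.

No order can be given among compound 2, compound 3 and compound 4. On these data alone, whether an amine or a carboxylic acid on this aromatic carbon would give a number clear of the limit stays open.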